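Working notes on a dichlorobenzylamine series, one compound pending

A few compounds are considered here, and "the series" means these few. Any claim that something is new, unique, unknown or untested is made for them only; others in the source may bear on it.

Measured so far:
compound 1, `CCOC(=O)c1sc(-c2ccccc2)nc1N1CCC(NCc2ccc(Cl)c(Cl)c2)CC1`: 18.1%
compound 2, `CCOC(=O)c1sc(-c2ccccc2)nc1N1CCC(NCc2ccc(Cl)cc2Cl)CC1`: 9.43%
compound 3, `CCOC(=O)c1sc(-c2ccccn2)nc1N1CCC(NCc2ccc(Cl)c(Cl)c2)CC1`: 30.1%

In an ADME assay on RAW264.7 cells (Mus musculus) for cytotoxicity, read by MTT assay, with a stated time of 72 h, tested at 50 uM (on this read-out lower numbers stand for less inhibition and higher numbers for more inhibition at the one concentration tested (going by the name of the read-out)), compound 1 gives 18.1%. Compound 2 carries 2,4-dichlorophenyl in place of 3,4-dichlorophenyl on a saturated chain carbon bound to an amine nitrogen and in this assay compound 2 gives 9.43%; the step is a number 8.7 percentage points lower from compound 1 to compound 2 (within the scatter). Compound 3 differs from compound 1 by pyridin-2-yl in place of phenyl on an aromatic carbon and in this assay compound 3 gives 30.1%; the step is a number 12 percentage points higher from compound 1 to compound 3 (beyond the scatter), and compound 3 stands highest of the three.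

Compound 4, `CCOC(=O)c1sc(-c2ccccn2)nc1N1CCC(NCc2ccc(Cl)cc2Cl)CC1`, awaits measurement in this assay. It differs from compound 3 by 2,4-dichlorophenyl in place of 3,4-dichlorophenyl on a saturated chain carbon bound to an amine nitrogen, the same change, at the same place, as that from compound 1 to compound 2; the two cores differ in the way already given for compound 1 and compound 3.

Going by the values given here, only one earlier instance of this change exists, so the expectation is loose. Among the compounds with values here, the step from compound 3 to compound 4 is expected to be a number 8.1 percentage points lower from compound 3 to compound 4 (within the scatter), resting on the single earlier step of a number 8.7 percentage points lower from compound 1 to compound 2 (within the scatter). Compound 4 is therefore estimated at 22%, expected to fall between 8% and 36%.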

Compound 4, a percentage reported as inhibition, at one concentration (the size of the read-out at that concentration, not a potency): 18.6%
Beside the measured number, compound 4's estimate is 3.4 percentage points above it, and the stated range covers the measured number.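

In this assay, the change from 3,4-dichlorophenyl to 2,4-dichlorophenyl carries over from the core of compound 1 to the core of compound 3, the new step being a number 11.5 percentage points lower from compound 3 to compound 4 (beyond the scatter), and the two steps do not differ: the same change on two cores in this assay, a number 8.7 percentage points lower (within the scatter) from compound 1 to compound 2 and a number 11.5 percentage points lower (beyond the scatter) from compound 3 to compound 4, 2.8 percentage points apart, within the scatter of two such steps. Pyridin-2-yl in place of phenyl also reads alike with either dichlorophenyl group, the step with 2,4-dichlorophenyl being a number 9.2 percentage points higher from compound 2 to compound 4 (within the scatter): the same change on two cores in this assay, a number 12 percentage points higher (beyond the scatter) from compound 1 to compound 3 and a number 9.2 percentage points higher (within the scatter) from compound 2 to compound 4, 2.8 percentage points apart, within the scatter of two such steps. The two changes therefore behave as independent within these four compounds, but this is one set of paired steps at a single concentration, and it shows neither why the numbers move nor that the change would carry to any other core.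

The compounds shown leave open whether the same step would appear with pyridin-3-yl or a thiophene in place of pyridin-2-yl, or with a carboxylic acid or an amide in place of the ethyl ester. Also open, as far as these compounds go, is whether a single chlorine or a trifluoromethyl group on the benzyl ring would follow the same course.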